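Repeating an Isopropyl Substitution Across Two Related Cores

The source may report more compounds than this note shows. Statements on the series, on what has been measured and on what is new or still open speak of the compounds shown alone.

Compound 1 `O=C(NCCNS(=O)(=O)c1sccc1-c1ccccc1Oc1ccc(O)c(O)c1)Nc1cc(Cl)cc(Cl)c1` and compound 2 `CC(C)c1ccc(Oc2ccc(O)c(O)c2)c(-c2ccsc2S(=O)(=O)NCCNC(=O)Nc2cc(Cl)cc(Cl)c2)c1` share one core and differ at a single place: isopropyl in place of hydrogen on an aromatic carbon. In a functional assay on RS4-11 cells (Homo sapiens) for inhibition, read by CCK-8 assay, with a stated time of 48 h (a higher number here means a weaker inhibitor, a lower number a stronger inhibitor), compound 1 gives 6200 nM, while compound 2 gives 6400 nM. The step of a 1.0-fold higher number from compound 1 to compound 2 (0.01 log units; within the scatter) leaves the two compounds within the scatter of each other, so this change did nothing measurable on that core.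

Compound 3 `O=C(NCCNS(=O)(=O)c1sccc1-c1ccccc1Oc1ccc(O)c(O)c1)Nc1cc(C(F)(F)F)cc(C(F)(F)F)c1` is built on a second core; the difference between the two cores is not broken down here. In this assay compound 3 gives 4900 nM, a number within the scatter of both compound 1 and compound 2.

Compound 4 `CC(C)c1ccc(Oc2ccc(O)c(O)c2)c(-c2ccsc2S(=O)(=O)NCCNC(=O)Nc2cc(C(F)(F)F)cc(C(F)(F)F)c2)c1` has not yet been measured. It stands to compound 3 exactly as compound 2 stands to compound 1, the same change at a place described in the same words: isopropyl in place of hydrogen on an aromatic carbon. Because the earlier step of a 1.0-fold higher number from compound 1 to compound 2 (0.01 log units; within the scatter) lay within the scatter, the step from compound 3 to compound 4 is expected to be similarly small, about a 1.0-fold higher number from compound 3 to compound 4 (0.01 log units; within the scatter). Compound 4 is therefore estimated at 5000 nM, with a likely range from 2500 nM to 10000 nM.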

Compound 4, half-maximal inhibitory concentration: 6800 nM
Beside the measured number, compound 4's estimate is 1.4-fold (0.13 log units) below it; the range from low to high includes it.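

On the second core, the isopropyl change gives a 1.4-fold higher number from compound 3 to compound 4 (0.14 log units; within the scatter) in this assay, so here too the change has no measurable effect on the number. Set beside the step on the first core, this result shows no difference in how the change behaves on the two cores: the same change on two cores in this assay, a 1.0-fold higher number (0.01 log units; within the scatter) from compound 1 to compound 2 and a 1.4-fold higher number (0.14 log units; within the scatter) from compound 3 to compound 4, 1.3-fold (0.13 log units) apart, within the scatter of two such steps. Going by these compounds alone, what carries over from one core to the other is therefore the absence of a measurable effect, seen in only two matched pairs in one assay; this does not show that the change would be as silent on any other core, or that it would leave other read-outs unchanged.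

All four compounds carry the 3,4-dihydroxyphenoxy group, and isopropyl is the only group shown in place of that hydrogen. On these data alone, whether an amine or a carboxylic acid at the same place would shift the number in this assay stays open, as does whether either core would tolerate a longer chain there.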